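From 4-methylphenyl to 3-fluorophenyl in compound 4

The source may report more compounds than this note shows. Statements on the series, on what has been measured and on what is new or still open speak of the compounds shown alone.

In a functional assay on HT-29 cells (Homo sapiens) for inhibition, read by CCK-8 assay, with a stated time of 24 h (a lower number here means a stronger inhibitor, a higher number a weaker inhibitor), compound 1 `O=C1Nc2ccccc2/C1=C/c1ccc(-c2cn(-c3ccc(F)cc3)nn2)cc1` gives 17700 nM. Compound 2 `O=C1Nc2ccccc2/C1=C/c1ccc(-c2cn(-c3cccc(Cl)c3)nn2)cc1` gives > 20000 nM, which is a limit of the assay and not a number. Compound 3 `Cc1ccc(-n2cc(-c3ccc(/C=C4\C(=O)Nc5ccc(F)cc54)cc3)nn2)cc1`, at 3980 nM, has the lower of the two actual numbers, and its gap to compound 1 lies beyond the scatter.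

Compound 4 `O=C1Nc2ccc(F)cc2/C1=C/c1ccc(-c2cn(-c3cccc(F)c3)nn2)cc1` keeps the core of compound 3 but carries 3-fluorophenyl in place of 4-methylphenyl on an aromatic nitrogen, a change counted as 3-fluorophenyl in place of 4-methylphenyl on an aromatic nitrogen. Going by the values given here, only one measured step bears on this group: an at least 1.1-fold higher number from compound 1 to compound 2 (0.05 log units; that floor lies within the scatter). It replaces 4-fluorophenyl with 3-chlorophenyl, and because it ends at a limit, it gives only a floor, which lies within the scatter. On that thin basis, only a small move towards a higher number is expected. The estimated step is a 1.5-fold higher number from compound 3 to compound 4 (0.18 log units; within the scatter) in this assay, and it is expected to stay close to the scatter. For compound 4 the estimate is 6000 nM, with an expected range from 2500 nM to 15000 nM.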

Compound 4, half-maximal inhibitory concentration: > 12900 nM
Compound 4 gave a limit, no number (the forecaster's own chance of this, stated with the estimate: 10%); middle value at least 2.1-fold (0.33 log units) from the limit.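

In this assay, going by these compounds alone, the swap of 4-methylphenyl for 3-fluorophenyl on the aromatic nitrogen gives the first step at this position that lies beyond the scatter (an at least 3.2-fold higher number from compound 3 to compound 4 (0.51 log units; beyond the scatter)), so on the core of compound 3 this position is not indifferent to the group it carries. The earlier step at the same position (an at least 1.1-fold higher number from compound 1 to compound 2 (0.05 log units; that floor lies within the scatter)) offered only a floor within the scatter, on the core of compound 1. The new step is also only a floor, because compound 4 gave a limit of the assay and not a number: the limit of > 12900 nM in this assay, at which 1 of the 4 values shown sits.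

The compounds shown leave open how far compound 4 lies beyond its limit, and whether the loss follows the methyl group, the fluorine or the place of either on the phenyl ring. They also leave open how this position would respond to an amine or a carboxylic acid on that ring.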